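From benzyl to 2,4-dichlorobenzyl on compound 3

This account rests on a few compounds, and the source may have more. Where it says the series, first, only, none or still open, it means among the compounds named here.

Among the compounds with values here, in a functional assay on A549 cells (Homo sapiens) for antiproliferative activity, read by MTT assay, with a stated time of 48 h (on this read-out higher numbers stand for weaker inhibition and lower numbers for stronger inhibition), compound 3 `O=[N+]([O-])c1cc(C(F)(F)F)cc([N+](=O)[O-])c1Oc1ccc(Cl)cc1/C=N\OCc1ccccc1` gives 3410 nM, the highest number so far. Compound 1 `O=[N+]([O-])c1cc(C(F)(F)F)cc([N+](=O)[O-])c1Oc1ccccc1/C=N/OCc1ccccc1Cl` gives 1430 nM, and compound 2 `O=[N+]([O-])c1cc(C(F)(F)F)cc([N+](=O)[O-])c1Oc1ccccc1/C=N/OCc1ccc(Cl)cc1Cl` gives 1610 nM. Compound 4 `O=[N+]([O-])c1cc(C(F)(F)F)cc([N+](=O)[O-])c1Oc1ccc(Cl)cc1/C=N\OCc1ccc(Cl)cc1Cl` has 2,4-dichlorophenyl in place of phenyl on a saturated chain carbon bound to an oxygen. Within the data shown here, only one measured step bears on this change: a 1.1-fold higher number from compound 1 to compound 2 (0.05 log units; within the scatter), with chloro in place of hydrogen on an aromatic carbon. That step lies within the scatter, but it was measured on a different parent and covers only one added chloro, so it is a limited guide. No shift beyond the scatter is therefore expected in this assay. The expected step is a 1.2-fold lower number from compound 3 to compound 4 (0.09 log units; within the scatter). The estimate for compound 4 is 2800 nM, with an expected range of 1300 nM to 6000 nM.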

Compound 4, half-maximal inhibitory concentration: 3440 nM
The estimate for compound 4 lay 1.2-fold (0.09 log units) below the measured number; low and high end bracket the measured number.
By their numbers in this assay, from the lowest: compounds 1 and 2 (each within the scatter of the next); then compounds 3 and 4 (each within the scatter of the next).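

In this assay, replacing benzyl with 2,4-dichlorobenzyl gives a 1.0-fold higher number from compound 3 to compound 4 (0.00 log units; within the scatter). The earlier step covered one added chloro on a different parent, whereas this one covers both chloro groups together, starting from plain benzyl, and the two numbers lie within the scatter of each other. No measurement shown here explains this result. From the compounds shown here alone, it remains open whether an amine or a carboxylic acid on the phenyl, or a longer chain in place of benzyl, would also leave the number within the scatter.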